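The source may report more compounds than this note shows. Statements on the series, on what has been measured and on what is new or still open speak of the compounds shown alone.

Compound 1 `C=C1C(=O)[C@]23C[C@@]1(O)CC[C@H]2c1ccc(O)c(C)c1[C@@H]3Cn1cc(-c2ccccc2)nn1` and compound 2 `C=C1C(=O)[C@]23C[C@@]1(O)CC[C@H]2c1ccc(O)c(C)c1[C@@H]3Cn1cc(-c2ccccn2)nn1` share one core and differ only in the aromatic group carried on a five-membered aromatic ring with three nitrogens. Both were tested in a functional assay on HL-60 cells (Homo sapiens) for cytotoxicity, read by MTT assay, with a stated time of 4 days; on this read-out lower numbers stand for stronger inhibition and higher numbers for weaker inhibition. In this assay compound 1 gives 750 nM, and compound 2 gives 1970 nM. The change between them is phenyl in place of pyridin-2-yl on an aromatic carbon, and it brought a 2.6-fold lower number from compound 2 to compound 1 (0.42 log units; beyond the scatter).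

Compound 3 `C=C1C[C@]23C[C@@]1(O)CC[C@@H]2c1cccc(C)c1[C@@H]3Cn1cc(-c2ccccn2)nn1` carries the same pyridin-2-yl group on a different core; the difference between the core of compound 3 and the core of compound 2 is not broken down here. In this assay compound 3 reaches only a limit, > 20000 nM, which is the edge of what the assay reports rather than a number. Compound 3 thus sits at the limit of > 20000 nM in this assay, at which 1 of the 3 values shown sits.

Compound 4 `C=C1C[C@]23C[C@@]1(O)CC[C@@H]2c1cccc(C)c1[C@@H]3Cn1cc(-c2ccccc2)nn1` is the partner of compound 3, made by phenyl in place of pyridin-2-yl on an aromatic carbon. The surroundings of the change read the same, word for word, as in the step from compound 2 to compound 1, so this is the same change on another core. From compound 3 to compound 4 a step of about the same modest size is expected, resting on the measured step of a 2.6-fold lower number from compound 2 to compound 1 (0.42 log units; beyond the scatter), so that compound 4 is expected to move by a step that the limit leaves unreadable from compound 3 to compound 4. Since compound 3 shows only a limit, compound 4 is expected to land near 25000 nM, somewhere between 8000 nM and 100000 nM, with a real chance that the assay again reports only a limit.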

Compound 4, half-maximal inhibitory concentration: > 20000 nM
Compound 4: no number, only a limit; the forecaster's own chance of this, stated with the estimate: 55%; the middle value does not contradict the limit.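

In this assay, compound 3 and compound 4 each report only a limit of the assay rather than a number, so no step can be read between them: the limit of > 20000 nM in this assay, at which 2 of the 4 values shown sit.

The compounds shown leave open whether phenyl in place of pyridin-2-yl changes the number at all on the core of compound 3, as it does on the core shared by compound 1 and compound 2.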